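The source may report more compounds than this note shows. Statements on the series, on what has been measured and on what is new or still open speak of the compounds shown alone.

Compound 1 `Cc1cc(-n2nccn2)cc(C(=O)NNS(=O)(=O)c2ccccc2)c1F`: 25 ug/mL
Compound 2 `C=CCOc1ccc(F)c(C(=O)NNS(=O)(=O)c2ccccc2)c1`: 50 ug/mL

In a physicochemical assay for solubility, read by nephelometry, measured as kinetic solubility, at pH 2 (on this read-out lower numbers stand for lower solubility and higher numbers for higher solubility), compound 1 gives 25 ug/mL, the lower of the two numbers shown, while compound 2 gives 50 ug/mL; the gap between them lies within the usual scatter, so the two cannot be told apart. Compound 3 `Cc1cc(-n2cccn2)cc(C(=O)NNS(=O)(=O)c2ccccc2)c1F` differs from compound 1 in one place: 1H-pyrazol-1-yl in place of 2H-1,2,3-triazol-2-yl on an aromatic carbon. Among the measured compounds shown here, no measured pair shows this change, so its effect is unknown here. The step is expected to be small, a 1.3-fold lower number from compound 1 to compound 3 (0.10 log units; within the scatter), not beyond the scatter. Compound 3 is therefore estimated at 20 ug/mL, with a range from 8 ug/mL to 50 ug/mL.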

Compound 3, solubility: 6.3 ug/mL
The estimate for compound 3 lay 3.2-fold (0.50 log units) above the measured number; measured number outside the range, below it.
By their numbers in this assay, from the lowest: compound 3; then compounds 1 and 2 (each within the scatter of the next).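

In this assay, the group on this aromatic carbon matters: putting 1H-pyrazol-1-yl in place of 2H-1,2,3-triazol-2-yl gives a 4.0-fold lower number from compound 1 to compound 3 (0.60 log units; beyond the scatter), even though both groups are five-membered aromatic rings of 5 heavy atoms. Among the compounds shown here, this is the first measured pair that isolates a single change at this position, and so far it is the only one. Nothing measured here explains the size of this step. Where an amine or a carboxylic acid on this aromatic carbon would fall in this assay remains open. So does whether this same ring swap would give a similar step on a different core.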